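Aryl variation in the methoxime series at the dopamine receptor

This account rests on a few compounds, and the source may have more. Where it says the series, first, only, none or still open, it means among the compounds named here.

Measured so far:
compound 1 `CO/N=C(\CCN1CCN(c2ccccn2)CC1)c1ccc(Cl)cc1`: 87%
compound 2 `CO/N=C(\CCN1CCN(c2ccccn2)CC1)c1cc(C)cc(C)c1`: 71%

In a functional assay on HEK293 cells with D(4) dopamine receptor (Homo sapiens) as the target, read by FLIPR (a higher number here means a larger maximal response, a lower number a smaller maximal response), compound 1 gives 87% and compound 2 gives 71%. Compound 2 stands lowest of the two numbers; its nearest neighbour is compound 1, and the step of a number 16 percentage points lower from compound 1 to compound 2 (beyond the scatter) lies beyond the scatter. Compound 3 `CO/N=C(\CCN1CCN(c2ccccn2)CC1)c1ccc(Cl)c(Cl)c1` has not yet been measured. Against compound 2 the change is 3,4-dichlorophenyl in place of 3,5-dimethylphenyl on a carbon with a double bond to nitrogen.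

Among the measured compounds shown here, only one measured step bears on this change: a number 16 percentage points lower from compound 1 to compound 2 (beyond the scatter), in which a chlorine-bearing phenyl gave way to the dimethyl-bearing one and the maximal response fell. For the measured compounds named here, the step to compound 3 runs in the opposite sense, back to a chlorine-bearing phenyl, so a rise in this assay of roughly that size is expected, although the second chlorine has no measured precedent and widens the uncertainty.

Compound 3 is therefore estimated at 82% with a range of 68% to 96%. The expected step is a number 11 percentage points higher from compound 2 to compound 3 (beyond the scatter).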

Compound 3, largest response reached (reported as efficacy), in percent of the reference or control that the assay uses: 79%
The estimate for compound 3 lay 3 percentage points above the measured number; measured number inside the range.
By their numbers in this assay, from the lowest: compounds 2, 3 and 1 (each within the scatter of the next, the first and the last beyond it).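

In this assay the aryl position on the carbon with a double bond to nitrogen accepts a further chloro on the 4-chlorophenyl group: the listed step is a number 8 percentage points lower from compound 1 to compound 3 (within the scatter) and so the maximal response does not separate these two compounds. Replacing 3,5-dimethylphenyl with 3,4-dichlorophenyl gives a number 8 percentage points higher from compound 2 to compound 3 (within the scatter) and so compound 3 cannot be told apart from compound 2 either, leaving only compound 1 and compound 2 separated by more than the scatter. No measurement shown here offers an explanation for these numbers.

Still open, going by these compounds, is whether a nitrile or a methoxy group on the phenyl ring would take the response outside this narrow run. Also open, on these data alone, is how the response would change with an ethoxy group in place of the methoxy on the oxime nitrogen.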